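The compounds below may be only part of what the source reports. "The series", "measured", "known", "first", "only" and "open" are said of these compounds alone.

Series notes: a common core carrying a butyl ester at the end of the acyl chain, compound 1 `CCCCOC(=O)CCC(=O)N1CCN(CCCOc2cc3c(Nc4ccc(F)c(Cl)c4)ncnc3cc2OC)CC1`, a undecyl ester, compound 2 `CCCCCCCCCCCOC(=O)CCC(=O)N1CCN(CCCOc2cc3c(Nc4ccc(F)c(Cl)c4)ncnc3cc2OC)CC1`, and a dodecyl ester, compound 3 `CCCCCCCCCCCCOC(=O)CCC(=O)N1CCN(CCCOc2cc3c(Nc4ccc(F)c(Cl)c4)ncnc3cc2OC)CC1`. In a functional assay on A549 cells (Homo sapiens) for cytotoxicity, read by MTT assay, with a stated time of 24 h, tested at 20 uM (on this read-out higher numbers stand for a weaker effect at the one concentration tested and lower numbers for a stronger effect), compound 1 gives 86%. Compound 2 gives 85.2%. Compound 3 gives 86.8%. The three numbers sit together: the step reads a number 0.8 percentage points lower from compound 1 to compound 2 (within the scatter), then a number 0.8 percentage points higher from compound 1 to compound 3 (within the scatter), and a number 1.6 percentage points higher from compound 2 to compound 3 (within the scatter). Compound 3 thus stands inside the same band as the other two, separated from each by margins the assay cannot resolve.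

The next member is compound 4 `CCCCCCCCCCCCCCCOC(=O)CCC(=O)N1CCN(CCCOc2cc3c(Nc4ccc(F)c(Cl)c4)ncnc3cc2OC)CC1`. Relative to compound 3 the change is propyl in place of hydrogen on a saturated chain carbon, ten or more bonds along the chain from an oxygen next to a carbonyl group. The measured steps that bear on it are the chain extensions from compound 1 to compound 2, from compound 1 to compound 3 and from compound 2 to compound 3, each within the scatter; lengthening the ester chain has so far produced no effect the assay can distinguish. For compound 4 the expected step is a number 0.3 percentage points lower from compound 3 to compound 4 (within the scatter), none beyond the scatter. Compound 4 is therefore estimated at 86.5%, with a range of 78% to 94%.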

Compound 4, a percentage reported as activity, at one concentration (the size of the read-out at that concentration, not a potency): 91.2%
Compound 4: middle estimate off by 4.7 percentage points, on the low side, and the stated range covers the measured number.
By their numbers in this assay, from the lowest: compounds 2, 1, 3 and 4 (each within the scatter of the next).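

In this assay the propyl extension gives a number 4.4 percentage points higher from compound 3 to compound 4 (within the scatter) and so does not separate compound 4 from the dodecyl ester. Measured against the shorter esters, the read-out shows a number 6 percentage points higher from compound 2 to compound 4 (within the scatter) and a number 5.2 percentage points higher from compound 1 to compound 4 (within the scatter) in the same series, so even the widest chain differences shown here stay unresolved. The four saturated alkyl esters therefore form one band, now extended by propyl beyond compound 3, and no evidence available here bears on this result.

The compounds shown leave open whether any change at the chain end can move this read-out beyond the scatter, for example a free carboxylic acid or a terminal amine in place of the alkyl ester. They also leave open how a methyl ester, or a chain longer than that of compound 4, would read, and what these esters do at other concentrations, since a single concentration gives no potency.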